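Cytotoxicity notes on the aminomethylimidazole series

A few compounds are considered here, and "the series" means these few. Any claim that something is new, unique, unknown or untested is made for them only; others in the source may bear on it.

Compound 1 `COC(=O)c1ccc(NCc2cncn2Cc2ccccc2OC)cc1-c1ccccc1` is the reference point here. In a toxicity assay on NIH3T3 cells (Mus musculus) for cytotoxicity, read by resazurin assay (a higher number here means that more compound is needed for the effect, a lower number that less compound is needed), compound 1 stands at "not determined" (no result reported), so no number is available for it. Compound 2 `c1ccc(-c2ccc(Cn3cncc3CNc3ccc(-c4cncs4)c(-c4ccccc4)c3)cc2)cc1` shares the imidazole-methylamine linkage. In this assay compound 2 gives > 1000 nM, which is a limit of the assay and not a number. Of the two values shown, one sits at that limit (the limit of > 1000 nM in this assay, at which 1 of the 2 values shown sits).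

The step of interest leads from compound 1 to compound 3 `COC(=O)c1ccc(NCc2cncn2Cc2cccc(N)c2)cc1-c1ccccc1`. The change, counted from the two structures, is 3-aminophenyl in place of 2-methoxyphenyl on a saturated chain carbon bound to an aromatic nitrogen. For the measured compounds named here, with compound 1 lacking a number in this assay, no measured step between the two can be given, and the size of the change in this assay cannot be read from the compounds already measured.

Going by the values given here, what the series shows so far is only that compound 2 reaches no number and remains at the limit. On that basis compound 3 is expected to behave in a similar way, with an estimated value of 3000 nM in this assay, in a range from 800 nM to 12000 nM, and a good chance that only a limit is reported.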

Compound 3, half-maximal effective concentration: > 10000 nM
Compound 3 was reported as a limit; the forecaster's own chance of this, stated with the estimate: 70%; middle value at least 3.3-fold (0.52 log units) from the limit.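

In this assay compound 3 gives > 10000 nM, which is a limit of the assay and not a number. For the compounds shown here, with no number for compound 1, no step between compound 1 and compound 3 can be read. The compounds shown leave open how replacing 2-methoxyphenyl with 3-aminophenyl shifts the value in this assay.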